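Methoxy Addition on an Aromatic Carbon: Series Notes

This account rests on a few compounds, and the source may have more. Where it says the series, first, only, none or still open, it means among the compounds named here.

Measured compounds in a functional assay on RPMI-8226 cells (Homo sapiens) for cytotoxicity, read by sulforhodamine B assay, with a stated time of 48 h, tested at 0.01 uM; on this read-out higher numbers stand for a weaker effect at the one concentration tested and lower numbers for a stronger effect:
Compound 1 `COc1ccc(-c2cc(/C=C/C(=O)c3ccc(N)cc3)[nH]n2)cc1` gives 99%.
Compound 2 `COc1ccc(C(=O)/C=C/c2cc(-c3cc(OC)c(OC)c(OC)c3)n[nH]2)cc1OC` gives 94%.
Compound 3 `COc1ccc(-c2cc(/C=C/C(=O)c3ccc(N)cc3)[nH]n2)cc1OC` gives 98%.

All three numbers lie within the scatter of one another, so no order among them can be read from this assay. Within the data shown here, the one measured single-point change is methoxy in place of hydrogen on an aromatic carbon, and it gives a number 1 percentage points lower from compound 1 to compound 3 (within the scatter). The difference between the core of compound 1 and the core of compound 2 is not broken down here; the two values simply show the same order of read-out.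

Compound 4 `COc1cc(C(=O)/C=C/c2cc(-c3cc(OC)c(OC)c(OC)c3)n[nH]2)cc(OC)c1OC` is not yet measured. It differs from compound 2 by methoxy in place of hydrogen on an aromatic carbon. Among the measured compounds shown here, this is the same kind of change as the one from compound 1 to compound 3, not the same: in compound 4 the entering methoxy is also meta to a methoxy group, whereas around the place in compound 3 only the ortho methoxy group and the meta large group are present.

For compound 4 the expected step is a number 1 percentage points lower from compound 2 to compound 4 (within the scatter), because the same kind of change gave a number 1 percentage points lower from compound 1 to compound 3 (within the scatter) there, and compound 2 starts from 94%. Compound 4 is therefore estimated at 93% in this assay, with an expected range from 84% to 100%.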

Compound 4, a percentage reported as activity, at one concentration (the size of the read-out at that concentration, not a potency): 97%
Compound 4: the middle estimate sits 4 percentage points below what was measured, and the stated range covers the measured number.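

In this assay the new step is a number 3 percentage points higher from compound 2 to compound 4 (within the scatter), for methoxy in place of hydrogen on an aromatic carbon. Set beside the earlier step, the change gives no reading that distinguishes one core from the other, and the two steps agree as far as this read-out can tell: the same change on two cores in this assay, a number 1 percentage points lower (within the scatter) from compound 1 to compound 3 and a number 3 percentage points higher (within the scatter) from compound 2 to compound 4, 4 percentage points apart, within the scatter of two such steps. Among these compounds, this shows only that the change produces no step beyond the scatter on either of these two cores at the one concentration tested; it does not show that the change is without effect in general, that it carries over as a fixed step, or that the surroundings of the entering methoxy, which include a further meta methoxy group in compound 4, make no difference.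

On these data alone, whether a hydroxy group, an ethoxy group or a fluorine atom at the same place on the aromatic carbon would read any differently from methoxy remains open, as does the behaviour of a carboxylic acid on these cores. Also open, as far as these compounds go, is whether the same change would give a step beyond the scatter on either core at another concentration, or on a third core.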